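The compounds below may be only part of what the source reports. "The series", "measured", "known", "first", "only" and "open" are said of these compounds alone.

Among the measured compounds shown here, compound 3 `CCN(C/C=C/C#CC(C)(C)C)Cc1cccc(OCCN(C)S(=O)(=O)c2cccnc2)c1` gives 150 nM in a functional assay on HepG2 cells for inhibition of squalene monooxygenase (Homo sapiens) (a higher number here means a weaker inhibitor, a lower number a stronger inhibitor), the lowest of the three numbers so far. Compound 2 `CCN(C/C=C/C#CC(C)(C)C)Cc1cccc(OCCN(C)S(=O)(=O)c2nccs2)c1` gives 170 nM in this assay, and a 1.1-fold lower number from compound 2 to compound 3 (0.05 log units; within the scatter). Compound 1 `CCN(C/C=C/C#CC(C)(C)C)Cc1cccc(OCCN(C)S(=O)(=O)c2ccc(Br)cc2)c1` gives 330 nM in this assay, with a 2.2-fold lower number from compound 1 to compound 3 (0.34 log units; beyond the scatter) and a 1.9-fold lower number from compound 1 to compound 2 (0.29 log units; within the scatter). Compound 4 `CCN(C/C=C/C#CC(C)(C)C)Cc1cccc(OCCN(C)S(=O)(=O)c2ccc(-c3ccsc3)s2)c1` has not been measured; it differs from compound 3 by 5-(thiophen-3-yl)thiophen-2-yl in place of pyridin-3-yl on a sulfonyl sulfur. All three measured steps swap this same group on the sulfonyl sulfur and move the number at most modestly, so the change to compound 4 is expected to give a small step, if any, perhaps back toward where compound 1 stands. The step from compound 3 to compound 4 in this assay is estimated as a 2.0-fold higher number from compound 3 to compound 4 (0.30 log units; within the scatter). Compound 4 is expected to give 300 nM in this assay, between 110 nM and 850 nM.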

Compound 4, half-maximal inhibitory concentration: 210 nM
Beside the measured number, compound 4's estimate is 1.4-fold (0.15 log units) above it; the measured number falls inside the stated range.
By their numbers in this assay, from the lowest: compounds 3, 2, 4 and 1 (each within the scatter of the next, the first and the last beyond it).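

In this assay, a 1.4-fold higher number from compound 3 to compound 4 (0.15 log units; within the scatter) and a 1.2-fold higher number from compound 2 to compound 4 (0.09 log units; within the scatter) and a 1.6-fold lower number from compound 1 to compound 4 (0.20 log units; within the scatter) all lie within the scatter. So on this sulfonyl sulfur, 5-(thiophen-3-yl)thiophen-2-yl, with 2 five-membered aromatic rings and 10 heavy atoms, gives a number that cannot be told apart from those of the groups with one ring, including pyridin-3-yl with 6 heavy atoms. No measurement shown offers an explanation for this. Still open, as far as these compounds go, is how an amine, a carboxylic acid or a simple alkyl chain on this sulfonyl sulfur would compare.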